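The compounds below may be only part of what the source reports. "The series", "measured", "known", "first", "only" and "open" are said of these compounds alone.

Compound 1 `CC(=O)NC12CCCC3CC(CCC31)C2` carries an acetamido group on its saturated core, a fused or bridged system of three rings. Among the measured compounds shown here, in an ADME assay (Gallus gallus) for cytotoxicity, read by microscopy, with a stated time of 24 h (on this read-out lower numbers stand for higher toxicity in this test and higher numbers for lower toxicity in this test), compound 1 gives 3000000 nM, the highest of the two numbers measured so far, which here means the lowest toxicity. Compound 2 `O[C@@H]1C2CCCC3C[C@@H]1CC[C@@H]32`, whose core bears a hydroxyl group instead, gives 750000 nM in this assay, a number below that of compound 1 by a margin beyond the usual scatter. For the measured compounds named here, no pair of measured compounds differs in a single place, so no measured step shows how one change moves this read-out.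

Compound 3 `O=C(O)C12CCCC3CC(CCC31)C2` differs from compound 1 in one place: carboxy in place of acetamido on a saturated ring carbon. Nothing measured here tells what this exchange does to cytotoxicity, and the leaving and entering groups match in their counted donor and acceptor. Compound 3 is therefore expected to land near compound 1, with the step of a 1.5-fold lower number from compound 1 to compound 3 (0.18 log units; within the scatter) estimated to stay within the scatter, in no clear direction. The expected value for compound 3 is 2000000 nM, with a range from 500000 nM to 6000000 nM.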

Compound 3, minimum cytotoxic concentration: 10000000 nM
The estimate for compound 3 lay 5.0-fold (0.70 log units) below the measured number, and the stated range ends below it.
By their numbers in this assay, from the lowest: compound 2; then compound 1; then compound 3.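

Among the compounds shown here, the exchange of acetamido for carboxy on this saturated ring carbon is the first single change that can be read on the shared core, and in this assay it gives a 3.3-fold higher number from compound 1 to compound 3 (0.52 log units; beyond the scatter), which on this read-out means lower toxicity in this test. This position therefore responds to the group it carries, even though the leaving and entering groups match in their counted donor and acceptor, so those counts alone do not settle the read-out for this pair. No measured property of either group bears on this step, and the reason for the shift remains unknown.

Going by these compounds, whether an amine or a methyl ester on the same ring carbon would raise the number, lower it or leave it within the scatter remains open, as does whether the exchange of acetamido for carboxy would act in the same way elsewhere on the core. The hydroxyl group of compound 2 also remains outside this comparison, since no single change connects compound 2 with compound 1 or compound 3.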